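Swapping ethynyl for methyl on a weak kinase-type series

A few compounds are considered here, and "the series" means these few. Any claim that something is new, unique, unknown or untested is made for them only; others in the source may bear on it.

Measured so far:
Compound 1 `Cc1cccc(Nc2nc(-c3ccnc(-c4ccccc4)c3)cs2)c1` gives 19100 nM; 19500 nM (2 entries) in a functional assay on RCC4 cells (Homo sapiens) for inhibition, read by XTT assay, with a stated time of 4 days; on this read-out lower numbers stand for stronger inhibition and higher numbers for weaker inhibition.
Compound 2 `Cc1cccc(Nc2nc(-c3ccnc(N4CCN(C)CC4)c3)cs2)c1` gives 11500 nM; 11700 nM (2 entries) in this assay.
Compound 3 `C#Cc1cc(-c2csc(Nc3cccc(C)c3)n2)ccn1` gives 18200 nM in this assay.

All three compounds share one core and differ only in the group attached to the pyridine-like ring at the far end. Compound 1 with its phenyl group the several entries of compound 1 in this assay, 19100 nM; 19500 nM (2 entries) and compound 2 with its methylpiperazine the several entries of compound 2 in this assay, 11500 nM; 11700 nM (2 entries) each give repeat entries that agree closely. Within the data shown here, compound 3 stands among them with the one number it shows; two further entries for compound 3 did not yield a single number.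

Compound 4 `Cc1cccc(Nc2nc(-c3ccnc(C)c3)cs2)c1` is not yet measured. It differs from compound 3 by a single change (methyl in place of ethynyl on an aromatic carbon). Among the measured compounds shown here, since every compound here sits in the same weak range, and no pair differing in one place has been measured, there is no basis for expecting a large move. The step from compound 3 to compound 4 is expected to be small, no larger than the scatter, in this assay: a 1.1-fold higher number from compound 3 to compound 4 (0.04 log units; within the scatter). Compound 4 is therefore estimated at 20000 nM, with a range from 8000 nM to 50000 nM.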

Compound 4, half-maximal inhibitory concentration: 28800 nM
The estimate for compound 4 lay 1.4-fold (0.16 log units) below the measured number, within the range that was stated.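

In this assay, among these compounds, putting methyl in place of ethynyl on an aromatic carbon next to the ring nitrogen gives a 1.6-fold higher number from compound 3 to compound 4 (0.20 log units; within the scatter) and provides the only step here between compounds that differ in one place. At this position, then, the triple bond and one carbon can go without a change that stands clear of the scatter, although the step rests on one number for each compound. Nothing measured here bears on why these two groups read alike.

Going by these compounds, whether an amine, a carboxylic acid or a longer chain such as propyl at this position would give a step beyond the scatter remains open. So does whether a change elsewhere on the shared core would do so.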